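This account rests on a few compounds, and the source may have more. Where it says the series, first, only, none or still open, it means among the compounds named here.

For the measured compounds named here, compound 2 `CC(=O)Nc1ccc(S(=O)(=O)NNc2ccc(Br)cc2)cc1` stands lowest of the two numbers so far in an assay for inhibition of Indoleamine 2,3-dioxygenase 1 (Homo sapiens), read by spectrophotometry, with stated times of 1 h and 4 h (on this read-out higher numbers stand for weaker inhibition and lower numbers for stronger inhibition), where compound 2 gives 130 nM, while compound 1 `CC(=O)Nc1ccc(S(=O)(=O)NNc2ccc(S(N)(=O)=O)cc2)cc1` gives 2480 nM. Going by the values given here, the single measured step, a 19-fold lower number from compound 1 to compound 2 (1.28 log units; beyond the scatter), concerns a different exchange on the same aromatic carbon. Compound 3 `CC(=O)Nc1ccc(S(=O)(=O)NNc2ccc(Br)c(F)c2)cc1` differs from compound 2 by fluoro in place of hydrogen on an aromatic carbon. Among the compounds with values here, no measured step bears on an added fluoro of this kind, so in this assay the expected step of a 1.1-fold lower number from compound 2 to compound 3 (0.03 log units; within the scatter) is none beyond the scatter. Compound 3 is therefore estimated at 120 nM, within a range from 45 nM to 320 nM.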

Compound 3, half-maximal inhibitory concentration: 205 nM
Estimate against measurement, compound 3: 1.7-fold (0.23 log units) below; measured number inside the range.
By their numbers in this assay, from the lowest: compounds 2 and 3 (each within the scatter of the next); then compound 1.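

In this assay, fluoro in place of hydrogen, ortho to a bromo group, is the first change shown at this position, and the step (a 1.6-fold higher number from compound 2 to compound 3 (0.20 log units; within the scatter)) stays within the scatter. So at this position, the added fluoro gives no difference that can be told from repeat measurement, unlike the large step at the sulfamoyl position. Nothing measured here accounts for this result. The compounds shown leave open how chloro, methyl, an amine or a carboxylic acid would read at this aromatic carbon in this assay. They also leave open whether fluoro would read the same without the bromo group.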